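Vinyl in place of ethynyl: half-life notes

A few compounds are considered here, and "the series" means these few. Any claim that something is new, unique, unknown or untested is made for them only; others in the source may bear on it.

Measured so far in a physicochemical assay for pharmacokinetics, read by LC-MS, in phosphate buffer, tested at 1 uM; a higher number here means that the compound lasts longer, a lower number that the compound disappears faster:
- compound 1 `CC#CCNC(=O)c1cccc2c1cc(C)n2-c1nc2c(c(NCc3ccccc3)n1)CCCC2` gives > 24 h, a limit of the assay, not a number
- compound 2 `CC#CCNC(=O)c1cccc2c1cc(C)n2-c1nc2c(c(NCc3ccccc3)n1)COCC2` gives > 24 h, a limit of the assay, not a number
- compound 3 `C#CC(=O)Nc1cccc2c1cc(C)n2-c1nc2c(c(NCc3ccccc3)n1)COCC2` gives 0.21 h

Within the data shown here, compound 3 holds the only true number in the set. Compound 1 and compound 2 both sit at the limit of > 24 h in this assay, at which 2 of the 3 values shown sit, so no order can be read between them.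

The next structure is compound 4 `C=CC(=O)Nc1cccc2c1cc(C)n2-c1nc2c(c(NCc3ccccc3)n1)COCC2`. The change is vinyl in place of ethynyl on a carbonyl carbon, which in words is vinyl in place of ethynyl on a carbonyl carbon.

Among the measured compounds shown here, one measured step bears on this: an at least 110-fold lower number from compound 2 to compound 3 (2.05 log units; beyond the scatter). That large step introduced the (ethynylcarbonyl)amino group, which is the group altered here. For the measured compounds named here, no measured pair swaps ethynyl for vinyl directly, so the size of the coming step is poorly bounded.

Compound 3 alone carries the ethynyl, and compound 3 gives 0.21 h. A rise beyond the scatter is therefore expected, recovering part of the drop but perhaps not all of it. The expected change is a 29-fold higher number from compound 3 to compound 4 (1.46 log units; beyond the scatter). For compound 4 the estimated half-life is 6 h, with an expected range from 1.5 h to 24 h.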

Compound 4, half-life: 4.31 h
Compound 4: the middle estimate sits 1.4-fold (0.14 log units) above what was measured, within the range that was stated.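

In this assay, among these compounds, this is the first pair that changes only the group on the carbonyl carbon whose other neighbour is the amide-type nitrogen, and it gives a 21-fold higher number from compound 3 to compound 4 (1.31 log units; beyond the scatter), so the short half-life of compound 3 follows the ethynyl and not the (ethynylcarbonyl)amino frame as a whole. The recovery is only partial, as a gap beyond the scatter remains with vinyl in place: an at least 5.5-fold lower number from compound 2 to compound 4 (0.74 log units; beyond the scatter). Compound 2 gives a limit of the assay, not a number, so that gap has no measured upper end: the limit of > 24 h in this assay, at which 2 of the 4 values shown sit.

Still open, on these data alone, is whether a saturated ethyl on the same carbonyl carbon, or a vinyl carrying a dimethylamino group, would last longer in this assay than the vinyl of compound 4. Also open, as far as these compounds go, are whether the step from ethynyl to vinyl keeps its size on the core of compound 1, and what removes these compounds from the buffer, as the half-lives alone do not identify any product of the loss.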